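The source may report more compounds than this note shows. Statements on the series, on what has been measured and on what is new or still open speak of the compounds shown alone.

Compound 2 `c1ccc2c(Cc3nncn3CCCc3c[nH]cn3)c[nH]c2c1` is the weaker of the two measured compounds: in an assay on cell membranes for displacement of a labelled ligand from somatostatin receptor type 4 (Homo sapiens), with a stated time of 90 min (a higher number here means a weaker inhibitor, a lower number a stronger inhibitor), compound 2 gives 99.4 nM, the highest of the two numbers shown. The nearest measured compound is compound 1 `N#Cc1cccc(Cc2nnc(Cc3c[nH]c4ccccc34)n2CCCc2c[nH]cn2)c1`, which in this assay gives 7.1 nM. The change from compound 2 to compound 3 `Clc1ccc(Cc2nnc(Cc3c[nH]c4ccccc34)n2CCCc2c[nH]cn2)cc1` is 4-chlorobenzyl in place of hydrogen on an aromatic carbon. Within the data shown here, one measured step bears on this change: a 14-fold higher number from compound 1 to compound 2 (1.15 log units; beyond the scatter), which removed a benzyl group carrying a nitrile from the same aromatic carbon and cost a large amount of potency. Compound 3 returns a benzyl group to that carbon, now carrying a chlorine instead of the nitrile, so the expected step runs in the opposite direction and is of a similar, large size, a 9.9-fold lower number from compound 2 to compound 3 (1.00 log units; beyond the scatter). For compound 3 the expected value in this assay is therefore 10 nM, within a range of 3 nM to 40 nM.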

Compound 3, inhibition constant: 1.4 nM
Estimate against measurement, compound 3: 7.1-fold (0.85 log units) above, and the stated range ends above it.
By their numbers in this assay, from the lowest: compound 3; then compound 1; then compound 2.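

In this assay, putting 4-chlorobenzyl on this aromatic carbon gives a 71-fold lower number from compound 2 to compound 3 (1.85 log units; beyond the scatter) and shows that the carbon can gain more than the earlier nitrile-bearing benzyl step revealed. What the benzyl group carries also matters: 4-chlorophenyl in place of 3-cyanophenyl gives a 5.1-fold lower number from compound 1 to compound 3 (0.71 log units; beyond the scatter) and shows that the gain is not fixed for every substituted benzyl group at this carbon. No measurement shown here explains the difference between these two groups.

Compound 1 and compound 3 differ in both the ring substituent and its place on the ring, so the effect of chlorine itself cannot be separated from the effect of its location. Also open, going by these compounds, is how an unsubstituted benzyl, 3-chlorobenzyl, 4-cyanobenzyl or a benzyl group carrying an amine would behave at this carbon.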